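A few compounds are considered here, and "the series" means these few. Any claim that something is new, unique, unknown or untested is made for them only; others in the source may bear on it.

Series notes. Three measured compounds share one core and differ at a single aromatic carbon. Compound 1 `O=S(=O)(Cc1nc(-c2ccc(Cl)nc2)c2sccc2n1)c1cccc(Cl)c1` carries a 6-chloropyridin-3-yl group there; in an ADME assay on cells (Homo sapiens) for cytotoxicity, read by resazurin assay, with a stated time of 5 days (on this read-out lower numbers stand for higher toxicity in this test and higher numbers for lower toxicity in this test), compound 1 gives 70000 nM. Compound 2 `COc1ccc(Nc2nc(CS(=O)(=O)c3cccc(Cl)c3)nc3ccsc23)cc1` carries (4-methoxyphenyl)amino instead, and in this assay compound 2 gives 60000 nM, so that a 1.2-fold lower number from compound 1 to compound 2 (0.07 log units; within the scatter). Compound 3 `COc1ccc(Oc2nc(CS(=O)(=O)c3cccc(Cl)c3)nc3ccsc23)cc1` carries 4-methoxyphenoxy; in this assay compound 3 gives only a limit of the assay, > 50000 nM. Compound 3 thus stands at the limit of > 50000 nM in this assay, at which 1 of the 3 values shown sits, and for that reason the steps a step that the limit leaves unreadable from compound 1 to compound 3 and a step that the limit leaves unreadable from compound 2 to compound 3 cannot be sized. The unmeasured compound 4 `O=c1ccc(-c2nc(CS(=O)(=O)c3cccc(Cl)c3)nc3ccsc23)c[nH]1` differs from compound 3 by a group of 7 heavy atoms (5 carbon, 1 nitrogen, 1 oxygen; one six-membered aromatic ring with 1 hetero atom) in place of a group of 9 heavy atoms (7 carbon, 2 oxygen; one six-membered aromatic ring of carbon only), on an aromatic carbon. For the measured compounds named here, no measured step touches this particular exchange, so it has no direct precedent. The readable values of compound 1 and compound 2 and the limit of compound 3 all sit in the same high region of this assay, and nothing among them suggests a change beyond the scatter, so compound 4 is expected to sit in that same region, with a fair chance that the assay again reports only a limit. The expected step is a step that the limit leaves unreadable from compound 3 to compound 4. Compound 4 is estimated at 60000 nM, between 25000 nM and 150000 nM.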

Compound 4, half-maximal cytotoxic concentration: > 50000 nM
Compound 4: no number, only a limit; the forecaster's own chance of this, stated with the estimate: 50%; the middle value does not contradict the limit.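

No new step can be read for compound 4, whose result in this assay is only a limit of the assay, > 50000 nM; its steps to compound 1, compound 2 and compound 3 all stay unreadable. Compound 4 joins compound 3 at the limit: the limit of > 50000 nM in this assay, at which 2 of the 4 values shown sit.

Going by these compounds, whether compound 3 and compound 4 differ from each other, or from compound 1 and compound 2, remains open.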